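A few compounds are considered here, and "the series" means these few. Any claim that something is new, unique, unknown or untested is made for them only; others in the source may bear on it.

Working notes on the series. In a functional assay on Huh-7 cells (Homo sapiens) for inhibition, read by sulforhodamine B assay, with a stated time of 72 h (a lower number here means a stronger inhibitor, a higher number a weaker inhibitor), compound 1 `COc1ccc2cc(C(C)c3nnc4n3N=C(c3ccc(Br)cc3)CS4)ccc2c1` gives 9300 nM. Among the three numbers in hand it stands second highest: compound 3 `CC(c1ccc(-c2ccccc2)c(F)c1)c1nnc2n1N=C(c1ccc(Cl)cc1)CS2` gives 3900 nM in this assay, a lower number beyond the scatter, while compound 2 `CC(c1ccc(-c2ccccc2)c(F)c1)c1n[nH]c(=S)n1N` gives 43100 nM in this assay, a higher number, also beyond the scatter. Compound 2 and compound 3 share a part of their structure that differs from compound 1, so neither pair is a single-point comparison and nothing more is read from them than the two values each.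

Compound 4 `COc1ccc2cc(C(C)c3nnc4n3N=C(c3ccc(Cl)cc3)CS4)ccc2c1` differs from compound 1 in one place: chloro in place of bromo on an aromatic carbon. For the measured compounds named here, no measured pair isolates this exchange. The step of a 1.2-fold lower number from compound 1 to compound 4 (0.07 log units; within the scatter) is expected to be small, no larger than the usual scatter, leaning if anything toward a lower number because compound 3 with its chloro group gives 3900 nM while differing elsewhere as well. Compound 4 is therefore estimated at 8000 nM, with a range from 3000 nM to 20000 nM.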

Compound 4, half-maximal inhibitory concentration: 5600 nM
The estimate for compound 4 lay 1.4-fold (0.15 log units) above the measured number; the measured number falls inside the stated range.
By their numbers in this assay, from the lowest: compounds 3, 4 and 1 (each within the scatter of the next, the first and the last beyond it); then compound 2.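

In this assay, for the compounds shown here, the exchange of 4-bromophenyl to 4-chlorophenyl gives a 1.7-fold lower number from compound 1 to compound 4 (0.22 log units; within the scatter) and so provides the first single-point comparison. On an aromatic carbon para to a large group, bromo and chloro are therefore not told apart on the core of compound 1, and this one exchange of halogen brings no step beyond the scatter. No measurement in hand bears on the reason for this result.

As far as these compounds go, whether a hydrogen, a methoxy group, an amine or a carboxylic acid at this place would bring a step beyond the scatter remains open. Also open, from the compounds shown here alone, is whether the same exchange of bromo for chloro would read the same way on a core carrying a different group in place of the methoxy-bearing part of compound 1.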